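Working notes: (morpholin-4-yl)carbonyl to 3-chlorobenzyl, compound 2 to 4

The compounds below may be only part of what the source reports. "The series", "measured", "known", "first", "only" and "open" are said of these compounds alone.

Measured so far in an assay for inhibition of MAP kinase-interacting serine/threonine-protein kinase 2 (Homo sapiens), read by luminescence and ADP-Glo, with a stated time of 2 h; on this read-out lower numbers stand for stronger inhibition and higher numbers for weaker inhibition:
Compound 1, `Nc1n[nH]c2cc(-c3ccc(=O)n(Cc4cccc(Cl)c4)c3)ccc12`; compound 1 gives 6 nM.
Compound 2, `O=C(N1CCOCC1)n1cc(-c2ccc3cn[nH]c3c2)ccc1=O`; compound 2 gives only the limit > 2000 nM.
Compound 3, `O=c1ccc(-c2ccc3cc[nH]c3c2)cn1Cc1ccccc1`; compound 3 gives only the limit > 2000 nM.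

Compound 2 stands at the limit of this assay, with no number of its own. Compound 3 sits at the same limit, as the limit of > 2000 nM in this assay, at which 2 of the 3 values shown sit, records. Only compound 1 carries a measured number. Among the compounds with values here, no pair among the three differs in a single place, so no measured step is available. Compound 4, `O=c1ccc(-c2ccc3cn[nH]c3c2)cn1Cc1cccc(Cl)c1`, is not yet measured. It differs from compound 2 by 3-chlorobenzyl in place of (morpholin-4-yl)carbonyl on an aromatic nitrogen. Within the data shown here, the same 3-chlorobenzyl is present in compound 1, the one compound with a number. The step from compound 2 to compound 4 is expected to run toward stronger inhibition in this assay, from a limit to a number, though its size cannot be taken from any measured step; the expected step is an at least 6.6-fold lower number from compound 2 to compound 4 (0.82 log units; beyond the scatter). Compound 4 is estimated at 300 nM, within 30 nM to 2500 nM.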

Compound 4, half-maximal inhibitory concentration: 40 nM
Compound 4: the middle estimate sits 7.5-fold (0.88 log units) above what was measured, and the stated range covers the measured number.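

Working notes, continued: in this assay, the group on the aromatic nitrogen now proves decisive, as 3-chlorobenzyl in place of (morpholin-4-yl)carbonyl gives an at least 50-fold lower number from compound 2 to compound 4 (1.69 log units; beyond the scatter). Compound 2 holds only a limit, so that step is bounded on one side only: the limit of > 2000 nM in this assay, at which 2 of the 4 values shown sit. The series also gains its first reading at the amino group, where hydrogen in place of amino on an aromatic carbon gives a 6.7-fold higher number from compound 1 to compound 4 (0.82 log units; beyond the scatter), a modest step showing that compound 4 keeps a measured number without the amino group.

Going by these compounds, whether the step at the nitrogen depends on the chlorine or on the benzyl as a whole remains open. Also open, on these data alone, is what a methyl, an unsubstituted benzyl or a longer chain ending in an amine would give at that nitrogen.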